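A few compounds are considered here, and "the series" means these few. Any claim that something is new, unique, unknown or untested is made for them only; others in the source may bear on it.

Of the compounds shown here, three built on one shared core have been measured in an assay for inhibition of Amine oxidase [flavin-containing] B (Homo sapiens), read by fluorescence and spectrophotometry, using microsomes, with stated times of 30 min and 20 min; a lower number here means a stronger inhibitor, a higher number a weaker inhibitor. Compound 1 `Clc1cccc(-c2nc(-c3cccc(C4=NCCN4)c3)no2)c1` gives 30 nM. Compound 2 `CC(C)(C)c1ccc(-c2noc(-c3ccc(C4=NCCN4)cc3)n2)cc1` gives 411 nM, and compound 3 `c1ncn(Cc2ccc(-c3noc(-c4ccc(C5=NCCN5)cc4)n3)cc2)n1` gives 9020 nM. Compound 3 thus carries the highest number of the three: it is a weaker inhibitor than compound 2, its nearest neighbour, and further still from compound 1. For the measured compounds named here, only one pair of measured compounds differs in a single place, and that step, a 22-fold higher number from compound 2 to compound 3 (1.34 log units; beyond the scatter), is large.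

Compound 4 `Cn1ccnc1SCc1ccc(-c2noc(-c3ccc(C4=NCCN4)cc3)n2)cc1` has not yet been measured. It differs from compound 3 in one place: (1-methyl-1H-imidazol-2-yl)sulfanyl in place of 1H-1,2,4-triazol-1-yl on a saturated chain carbon bound to an aromatic carbon. Going by the values given here, no measured step tests this kind of exchange, one five-membered ring for another on a saturated chain carbon bound to an aromatic carbon, because a 22-fold higher number from compound 2 to compound 3 (1.34 log units; beyond the scatter) concerns the arrival of such a ring in place of tert-butyl rather than a swap between rings. The expectation is therefore cautious: the number for compound 4 is expected to stay near that of compound 3, with the step of a 1.8-fold lower number from compound 3 to compound 4 (0.26 log units; within the scatter) expected to fall within or only modestly beyond the scatter. Compound 4 is estimated at 5000 nM, within a range from 1500 nM to 20000 nM.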

Compound 4, half-maximal inhibitory concentration: 2280 nM
For compound 4 the middle estimate is 2.2-fold (0.34 log units) above the measured one; measured number inside the range.
By their numbers in this assay, from the lowest: compound 1; then compound 2; then compound 4; then compound 3.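

In this assay, the exchange of 1H-1,2,4-triazol-1-yl for (1-methyl-1H-imidazol-2-yl)sulfanyl on a saturated chain carbon bound to an aromatic carbon gives a 4.0-fold lower number from compound 3 to compound 4 (0.60 log units; beyond the scatter), so the number at this position depends on which ring-bearing group is present, not only on the loss of tert-butyl. The gain is only partial: ((1-methyl-1H-imidazol-2-yl)sulfanyl)methyl in place of tert-butyl on an aromatic carbon still gives a 5.5-fold higher number from compound 2 to compound 4 (0.74 log units; beyond the scatter), a smaller rise than the triazole-bearing group produced. No available evidence accounts for this shift.

The exchange introduces a different ring, a sulfur and a methyl together, and the compounds shown do not separate these three parts. Also open, as far as these compounds go, is how a dimethylamino group or a carboxylic acid on the same chain carbon would read.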